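Adding One Fluoro to a Highly Active Compound

The source may report more compounds than this note shows. Statements on the series, on what has been measured and on what is new or still open speak of the compounds shown alone.

Measured so far in a functional assay on SiHa cells (Homo sapiens) for inhibition, read by CCK-8 assay, with a stated time of 72 h, tested at 10 uM; a higher number here means more inhibition of growth at the concentration tested, a lower number less inhibition of growth:
- compound 1 `CN(C)C(=O)c1cc2cnc(Nc3ccc(NC(=O)C4(C(=O)Nc5ccc(F)cc5)CC4)cc3)nc2n1C1CCCC1`: 98%
- compound 2 `CN(C)C(=O)c1cc2cnc(Nc3ccc(NC(=O)C4(C(=O)Nc5cccc(O)c5)CC4)cc3)nc2n1C1CCCC1`: 75.7%
- compound 3 `CN(C)C(=O)c1cc2cnc(Nc3ccc(NC(=O)C4(C(=O)Nc5ccccc5F)CC4)cc3)nc2n1C1CCCC1`: 103%

Compound 1 stands at the top of this small set together with compound 3, since the two lie within the scatter of each other: a number 5 percentage points higher from compound 1 to compound 3 (within the scatter). Compound 2 is the only clear outlier, with a number 22.3 percentage points lower from compound 1 to compound 2 (beyond the scatter).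

The next compound is compound 4 `CN(C)C(=O)c1cc2cnc(Nc3ccc(NC(=O)C4(C(=O)Nc5ccc(F)cc5)CC4)cc3F)nc2n1C1CCCC1`, which differs from compound 1 by a single change: fluoro in place of hydrogen on an aromatic carbon. The new fluoro sits on an aromatic carbon, ortho to a large group and meta to a large group. Within the data shown here, no measured step tests this change directly, because all three alter the aryl group on the amide-type nitrogen, on a different ring. The closest guide is the swap of one fluorophenyl group for another, a number 5 percentage points higher from compound 1 to compound 3 (within the scatter), which stayed within the scatter. The larger drop, a number 22.3 percentage points lower from compound 1 to compound 2 (beyond the scatter), came with a hydroxyphenyl group, which compound 4 does not carry.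

The estimated change is small, a number 5 percentage points lower from compound 1 to compound 4 (within the scatter), so no step beyond the scatter is expected. For compound 4 the expected value is 93%, with an estimated range from 76% to 105%.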

Compound 4, percent growth inhibition at one concentration: 44.4%
Estimate against measurement, compound 4: 48.6 percentage points above; the whole stated range lies above it.
By their numbers in this assay, from the lowest: compound 4; then compound 2; then compounds 1 and 3 (each within the scatter of the next).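

Among these compounds, until now every change sat on the aryl group on the amide-type nitrogen, so compound 4 gives the first look at a different ring, and in this assay the result is clear: a number 53.6 percentage points lower from compound 1 to compound 4 (beyond the scatter). This aromatic carbon, ortho to a large group and meta to a large group, is therefore sensitive, since exchanging hydrogen for fluoro adds just one heavy atom yet gives a larger step than either change of the aryl group away from the hydroxyphenyl compound, such as a number 5 percentage points higher from compound 1 to compound 3 (within the scatter) and a number 22.3 percentage points lower from compound 1 to compound 2 (beyond the scatter). Compounds 1 and 3 both carry a fluoro on the aryl group and keep high numbers, so in this small set the presence of a fluoro alone does not go with a loss, and its place in the molecule matters. Nothing measured here accounts for the drop.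

Going by these compounds, it remains open whether the loss belongs to fluoro in particular or to any group on this carbon, which a chloro, a methyl or a methoxy group there would help to show. On these data alone, it is also open whether the same fluoro would cost as much when paired with the 2-fluorophenyl group of compound 3.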